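Moving the acid and swapping fluorine for methyl on the aryl ether

A few compounds are considered here, and "the series" means these few. Any claim that something is new, unique, unknown or untested is made for them only; others in the source may bear on it.

Compound 1 `COc1ccc(C(=O)O)cc1OC[C@@H](C)Oc1ccc(C(=O)CC(C)(C)C)c(O)c1C` — 78 nM
Compound 2 `Cc1c(OC[C@H](C)COc2ccc(F)c(C(=O)O)c2)ccc(C(=O)CC(C)(C)C)c1O` — 294 nM
Compound 3 `Cc1c(OC[C@@H](C)COc2ccc(F)c(C(=O)O)c2)ccc(C(=O)CC(C)(C)C)c1O` — 112 nM

In an assay for positive allosteric modulation of metabotropic glutamate receptor 2 (Rattus norvegicus) (on this read-out higher numbers stand for an effect only at larger amounts of compound and lower numbers for an effect already at smaller amounts), compound 3 sits second highest of the three numbers, within the scatter of compound 1 and beyond it only against compound 2. Compound 4 `Cc1cc(C(=O)O)ccc1OC[C@H](C)COc1ccc(C(=O)CC(C)(C)C)c(O)c1C` differs from compound 3 by 4-carboxy-2-methylphenyl in place of 3-carboxy-4-fluorophenyl on an oxygen on a saturated carbon. Among the measured compounds shown here, the only measured step, a 2.6-fold lower number from compound 2 to compound 3 (0.42 log units; beyond the scatter), concerns configuration alone, as the fact that compounds 2 and 3 differ only in the configuration as drawn shows, and so says nothing about exchanging the aryl group. Compound 1 carries a differently substituted carboxyphenyl and gives a number within the scatter of compound 3, which suggests no large shift. Compound 4 is therefore expected to show a 1.0-fold lower number from compound 3 to compound 4 (0.01 log units; within the scatter), no step beyond the scatter, with an estimate of 110 nM in this assay, ranging from 35 nM to 350 nM.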

Compound 4, half-maximal effective concentration: 446 nM
Compound 4: the middle estimate sits 4.1-fold (0.61 log units) below what was measured; the measured number lies above the stated range.
By their numbers in this assay, from the lowest: compounds 1 and 3 (each within the scatter of the next); then compounds 2 and 4 (each within the scatter of the next).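

Among the compounds shown here, until now the only measured step concerned configuration; this result shows that the aryl group on this oxygen matters as well, since 4-carboxy-2-methylphenyl in place of 3-carboxy-4-fluorophenyl gives a 4.0-fold higher number from compound 3 to compound 4 (0.60 log units; beyond the scatter). Both groups have the same heavy-atom count, so that count alone does not decide the number. Nothing measured here gives a cause for this step.

On these data alone, the change moves the carboxylic acid and exchanges fluorine for methyl together, so the share of each remains open. So does the effect of an amide or a nitrile on this ring.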